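The compounds below may be only part of what the source reports. "The series", "measured", "known", "first", "only" and "open" are said of these compounds alone.

Measured in a functional assay on HL-60 cells (Homo sapiens) for cytotoxicity, read by MTT assay, with a stated time of 4 days; on this read-out lower numbers stand for stronger inhibition and higher numbers for weaker inhibition:
Compound 1 `C=C1C[C@]23C[C@@]1(O)CC[C@H]2c1ccc(O)c(C)c1[C@@H]3Cn1cc(-c2ccc(Br)cc2)nn1`: > 20000 nM, a limit of the assay.
Compound 2 `C=C1C[C@]23C[C@@]1(O)CC[C@H]2c1ccc(O)c(C)c1[C@@H]3Cn1cc(-c2ccc(C)cc2)nn1`: > 20000 nM, a limit of the assay.
Compound 3 `C=C1C[C@]23C[C@@]1(O)CC[C@H]2c1cc(Br)c(O)c(C)c1[C@@H]3Cn1cc(-c2ccc(Cl)cc2)nn1`: 5590 nM.

Within the data shown here, compound 3 holds the only number in this assay. The two other values sit at the limit of > 20000 nM in this assay, at which 2 of the 3 values shown sit, so compound 3 is the one point in the series that can be read. The step that the two limits leave unreadable from compound 1 to compound 2 has both ends at that limit and its size cannot be read.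

Compound 4 `C=C1C[C@]23C[C@@]1(O)CC[C@H]2c1ccc(O)c(C)c1[C@@H]3Cn1cc(-c2ccc(Cl)cc2)nn1` differs from compound 3 by hydrogen in place of bromo on an aromatic carbon. Among the measured compounds shown here, no measured step removes the bromo from the core ring, so nothing bears directly on the change. What the series does show is that compound 1 and compound 2, both lacking that bromo on the core, give only limits, whereas compound 3, carrying it, gives a number. Compound 4 returns to the core of compound 1 and compound 2 with a different aryl group, so a move toward the limit is expected, estimated as a 2.7-fold higher number from compound 3 to compound 4 (0.43 log units; beyond the scatter). For compound 4 the estimate in this assay is 15000 nM, expected to lie between 4000 nM and 60000 nM, with a fair chance that only a limit is reported.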

Compound 4, half-maximal inhibitory concentration: > 20000 nM
Compound 4: only a limit was reported; the forecaster's own chance of this, stated with the estimate: 55%; middle value at least 1.3-fold (0.12 log units) away from the limit.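

In this assay, the bromo ortho to the hydroxy group now has a direct reading: putting hydrogen in its place gives an at least 3.5-fold higher number from compound 3 to compound 4 (0.55 log units; beyond the scatter). Compound 1 and compound 2 each differ from compound 3 in two places, whereas this pair differs in one, with the chloro on the aryl group unchanged. Among the compounds shown, a number appears only with this bromo present, while the steps among compound 1, compound 2 and compound 4 cannot be read, all three ending at the same limit: the limit of > 20000 nM in this assay, at which 3 of the 4 values shown sit.

The full size of the step stays open, as does whether the bromo gives a number when the aryl group carries bromo or methyl in place of chloro, as no compound shown pairs either of these with the bromo on the core. Also open, going by these compounds, is whether the number depends on bromo itself or whether another group on that carbon, such as fluoro, iodo, a methoxy group or an amine, would also give a readable value.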